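This account rests on a few compounds, and the source may have more. Where it says the series, first, only, none or still open, it means among the compounds named here.

Measured compounds:

Compound 1, `CCCCCC(CCO)n1cnc2c(Cl)ncnc21`. In a functional assay on SW480 cells (Homo sapiens) for antiproliferative activity, read by MTT assay, with a stated time of 48 h (a lower number here means a stronger inhibitor, a higher number a weaker inhibitor), compound 1 reaches only the limit of the assay, > 50000 nM.
Compound 2, `CCCCCC(CCO)n1cnc2c(Cl)nc(Cl)nc21`. In this assay compound 2 gives 6010 nM.
Compound 3, `CCCCCCCCC(CCO)n1cnc2c(N)ncnc21`. In this assay compound 3 gives 20700 nM.

The change from compound 1 to compound 2 is chloro in place of hydrogen on an aromatic carbon. It brought an at least 8.3-fold lower number from compound 1 to compound 2 (0.92 log units; beyond the scatter). The size of that step is known only as a bound because compound 1 sits at the limit of > 50000 nM in this assay, at which 1 of the 3 values shown sits.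

Compound 3 differs from compound 1 in more than one place, and the difference between the two cores is not broken down here. Of the two numbers measured in this assay, compound 3 has the higher one; compound 2 is its nearest neighbour, and the gap between them lies beyond the scatter.

Compound 4, `CCCCCCCCC(CCO)n1cnc2c(N)nc(Cl)nc21`, has not yet been measured in this assay. It differs from compound 3 by chloro in place of hydrogen on an aromatic carbon. This is the same kind of change as from compound 1 to compound 2, though the surroundings are not identical: in compound 2 the entering chloro is meta to a chloro group, while in compound 4 it is meta to an amino group.

From compound 3 to compound 4 the expected step is a 5.2-fold lower number from compound 3 to compound 4 (0.71 log units; beyond the scatter), a lowering of the number. Among the compounds with values here, that expectation rests on the one earlier example of this kind of change, an at least 8.3-fold lower number from compound 1 to compound 2 (0.92 log units; beyond the scatter), although that example gives only a bound and the surroundings differ. Compound 4 is therefore estimated at 4000 nM, most likely between 1500 nM and 12000 nM.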

Compound 4, half-maximal inhibitory concentration: 13100 nM
For compound 4 the middle estimate is 3.3-fold (0.52 log units) below the measured one, and the stated range ends below it.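

On the core of compound 3, chloro in place of hydrogen on an aromatic carbon brought a 1.6-fold lower number from compound 3 to compound 4 (0.20 log units; within the scatter) in this assay, so on this core the change cannot be told apart from repeat measurement. The change therefore did not carry over at the same size from one core to the other, and its effect in this series cannot be read as a fixed increment: the same change on two cores in this assay, an at least 8.3-fold lower number (0.92 log units; beyond the scatter) from compound 1 to compound 2 and a 1.6-fold lower number (0.20 log units; within the scatter) from compound 3 to compound 4, at least 5.2-fold (0.72 log units) apart, beyond the scatter of two such steps What this does not show is the true size of the step on the core of compound 1, or which of the several differences between the two cores goes with the gap, and compound 1 enters the comparison only as a limit of the assay: the limit of > 50000 nM in this assay, at which 1 of the 4 values shown sits.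

The compounds shown leave open whether the smaller step goes with the amino group or with the longer chain, and a compound joining the amino group to the shorter chain of compound 1 would separate the two. They also leave open how the same place in the series would respond to a group other than chloro, such as bromo or methyl, on either core.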